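A few compounds are considered here, and "the series" means these few. Any claim that something is new, unique, unknown or untested is made for them only; others in the source may bear on it.

Compound 1 `N=C(N)N/N=C/c1c(-c2ccccn2)nc2sc(Cl)cn12`; in a functional assay (Homo sapiens) for antiproliferative activity (on this read-out lower numbers stand for stronger inhibition of growth and higher numbers for weaker inhibition of growth), compound 1 gives 8910 nM.
Compound 2 `Cc1sc2nc(-c3ccncc3)c(/C=N/NC(=N)N)n2c1C`; in this assay compound 2 gives 43700 nM.
Compound 3 `Cc1cn2c(/C=N/NC(=N)N)c(-c3ccccn3)nc2s1`; in this assay compound 3 gives 8910 nM.

Compound 1 stands level with compound 3, the two together the lowest of the three numbers, while compound 2 shows a clearly higher number. Among the measured compounds shown here, the one single-point step, no change at the digits printed from compound 1 to compound 3 (within the scatter), shows that methyl in place of chloro leaves the number where it was. Compound 4 `N=C(N)N/N=C/c1c(-c2cccnc2)nc2sc(Cl)cn12` differs from compound 1 by pyridin-3-yl in place of pyridin-2-yl on an aromatic carbon. For the measured compounds named here, no measured step moves the ring nitrogen of the pyridyl group, and compound 2 differs from compound 1 in more than one place, so nothing measured bears directly on this change. Compound 4 is therefore expected near compound 1, with a weak bias toward a higher number, a 1.7-fold higher number from compound 1 to compound 4 (0.23 log units; within the scatter), estimated at 15000 nM within 5000 nM to 50000 nM.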

Compound 4, concentration for 50% growth inhibition: 16600 nM
Compound 4: middle estimate off by 1.1-fold (0.04 log units), on the low side; the measured number falls inside the stated range.
By their numbers in this assay, from the lowest: compounds 1, 3 and 4 (each within the scatter of the next); then compound 2.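

The first measured move of the ring nitrogen of the pyridyl group, pyridin-3-yl in place of pyridin-2-yl on this aromatic carbon, gives in this assay a 1.9-fold higher number from compound 1 to compound 4 (0.27 log units; within the scatter) and so stays inside the usual variation between repeats. On this read-out, compounds 1 and 4 are not told apart, so this one change of attachment point on the pyridine ring shows no measurable consequence. No measurement shown offers a cause for this result. The compounds shown leave open how a phenyl ring at this position, or an amine on the pyridyl ring, would read.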